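Aryl amide variation on a shared chromone-acetamide core

This account rests on a few compounds, and the source may have more. Where it says the series, first, only, none or still open, it means among the compounds named here.

Measured in an assay on isolated protein for inhibition of Rho-associated protein kinase 2 (Homo sapiens), read by scintillation counting, radiometric assay and 33P incorporation, with a stated time of 40 min, in the presence of a further agent that is not named here; on this read-out higher numbers stand for weaker inhibition and lower numbers for stronger inhibition:
compound 1 `CCc1ccc(C(=O)Nc2cccc(NC(=O)COc3ccc4c(=O)ccoc4c3)c2)cc1`: 24 nM
compound 2 `N#Cc1ccc(C(=O)Nc2cccc(NC(=O)COc3ccc4c(=O)ccoc4c3)c2)cc1`: 15 nM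
compound 3 `O=C(COc1ccc2c(=O)ccoc2c1)Nc1cccc(NC(=O)c2ccc(OC(F)(F)F)cc2)c1`: 77 nM

Compound 3 gives the highest number of the three in this assay: the step from compound 1 to compound 3 is a 3.2-fold higher number from compound 1 to compound 3 (0.51 log units; beyond the scatter) and that from compound 2 to compound 3 is a 5.1-fold higher number from compound 2 to compound 3 (0.71 log units; beyond the scatter), whereas the step from compound 1 to compound 2 is a 1.6-fold lower number from compound 1 to compound 2 (0.20 log units; within the scatter).

Compound 4 `O=C(COc1ccc2c(=O)ccoc2c1)Nc1cccc(NC(=O)c2cccc([N+](=O)[O-])c2)c1` differs from compound 3 by 3-nitrophenyl in place of 4-(trifluoromethoxy)phenyl on a carbonyl carbon. All three measured steps change the group on this same carbonyl carbon; none of them introduces a nitrophenyl, so they only show that such exchanges move this assay by modest amounts. For compound 4 a number somewhat lower than compound 3 is therefore expected, a step of a 1.9-fold lower number from compound 3 to compound 4 (0.28 log units; within the scatter). The estimate for compound 4 in this assay is 40 nM, range 15 nM to 110 nM.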

Compound 4, half-maximal inhibitory concentration: 41 nM
For compound 4 the middle estimate is 1.0-fold (0.01 log units) below the measured one, within the range that was stated.
By their numbers in this assay, from the lowest: compounds 2, 1, 4 and 3 (each within the scatter of the next, the first and the last beyond it).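

In this assay, 3-nitrophenyl on this carbonyl carbon stays within the scatter of both 4-(trifluoromethoxy)phenyl (a 1.9-fold lower number from compound 3 to compound 4 (0.27 log units; within the scatter)) and 4-ethylphenyl (a 1.7-fold higher number from compound 1 to compound 4 (0.23 log units; within the scatter)). Of the earlier groups, only 4-cyanophenyl is separated from it (a 2.7-fold higher number from compound 2 to compound 4 (0.44 log units; beyond the scatter)), so a nitrophenyl fits within the span already seen at this position. No measurement on hand accounts for these differences.

A 4-nitrophenyl on this carbonyl carbon would separate the nitro group from its placing. An aminophenyl or a carboxyphenyl there would test whether this span holds for other kinds of group.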